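A few compounds are considered here, and "the series" means these few. Any claim that something is new, unique, unknown or untested is made for them only; others in the source may bear on it.

Measured so far: compound 1 `O=C(c1cccc(Cl)c1)c1ccn(-c2ccc3c(c2)B(O)OC3)c1` and compound 2 `O=C(c1ccc(O)cc1)c1ccn(-c2ccc3c(c2)B(O)OC3)c1`.

In an ADME assay on L929 cells (Mus musculus) for cytotoxicity, read by resazurin assay, with a stated time of 72 h (a higher number here means a weaker inhibitor, a lower number a stronger inhibitor), compound 1 gives > 10 ug/mL, a limit of the assay and not a number. In this assay compound 2 gives > 10 ug/mL, likewise a limit. The step that the two limits leave unreadable from compound 1 to compound 2 therefore cannot be read, and compound 2 stands only at that limit, where both values sit (the limit of > 10 ug/mL in this assay, at which 2 of the 2 values shown sit).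

Compound 3 `CCCCCC(=O)c1ccn(-c2ccc3c(c2)B(O)OC3)c1` is not yet measured. It differs from compound 2 by pentyl in place of 4-hydroxyphenyl on a carbonyl carbon. Among the measured compounds shown here, no measured step bears on a change of this kind, and the single step available, a step that the two limits leave unreadable from compound 1 to compound 2, is unreadable. Nothing here points in either direction, so no step beyond the scatter is expected. The estimate for compound 3 in this assay is 12 ug/mL, ranging from 4 ug/mL to 40 ug/mL. The expected step is a step that the limit leaves unreadable from compound 2 to compound 3. Most likely this assay again returns only a limit for compound 3.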

Compound 3, half-maximal inhibitory concentration: > 10 ug/mL
Compound 3: a limit, no number; the forecaster's own chance of this, stated with the estimate: 70%; the middle value is on the limit's open side.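

Among the compounds shown here, compound 1, compound 2 and compound 3 each return only a limit in this assay, so no step among them can be read: the limit of > 10 ug/mL in this assay, at which 3 of the 3 values shown sit. The compounds shown leave open whether any group on the carbonyl carbon would give a number rather than a limit in this assay.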